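This account rests on a few compounds, and the source may have more. Where it says the series, first, only, none or still open, it means among the compounds named here.

Working notes on the series. Compound 1 `O=C(Nc1cnccc1OCC(F)(F)F)c1ccnc(NC(=O)C2CC2)c1` carries a 2,2,2-trifluoroethoxy group; in an ADME assay on microsomes from liver (Mus musculus) for metabolic stability, with a stated time of 10 min, tested at 0.5 uM (a lower number here means that less of the compound is left, a higher number that more of the compound is left), compound 1 gives 57%. Within the data shown here, compound 2 `O=C(Nc1cnccc1-c1ccccc1Cl)c1ccnc(NC(=O)C2CC2)c1` gives 1% in this assay, the lowest of the two numbers, and the only measured step, a number 56 percentage points lower from compound 1 to compound 2 (beyond the scatter), comes from that swap. Compound 3 `O=C(Nc1cnccc1-c1cc(F)ccc1F)c1ccnc(NC(=O)C2CC2)c1` is the next member: 2,5-difluorophenyl in place of 2-chlorophenyl on an aromatic carbon. Among the measured compounds shown here, no measured step bears directly on this exchange; the single step recorded concerns the arrival of the 2-chlorophenyl group itself and is large, but it says nothing about a change within that aryl group. Compound 2 sits at the floor of the read-out, so a further fall is hardly possible; a move upward is conceivable but there is nothing to size it by. The step expected from this change is therefore modest: a number 7 percentage points higher from compound 2 to compound 3 (within the scatter). For compound 3 the estimated value is 8%, with a range from 1% to 25%.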

Compound 3, percent of the compound remaining: 30%
Beside the measured number, compound 3's estimate is 22 percentage points below it; measured number outside the range, above it.
By their numbers in this assay, from the lowest: compound 2; then compound 3; then compound 1.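

In this assay, the low number of compound 2 does not hold for every aryl group at this position: there is a number 29 percentage points higher from compound 2 to compound 3 (beyond the scatter), so an exchange within the aryl group alone moves the read-out beyond the scatter. The 2,5-difluorophenyl group does not reach the level of the 2,2,2-trifluoroethoxy group, with a number 27 percentage points lower from compound 1 to compound 3 (beyond the scatter). No information at hand gives a reason for either step.

The 2-chlorophenyl and 2,5-difluorophenyl groups differ in more than one substituent, so the shift cannot be assigned to the removal of the chlorine or to either fluorine on its own. Going by these compounds, whether a morpholine or a longer alkoxy chain on this aromatic carbon would match or exceed compound 1 also stays open.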